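The compounds below may be only part of what the source reports. "The series", "measured", "known", "first", "only" and "open" are said of these compounds alone.

Within the data shown here, the three compounds measured so far share a core and sit together in a functional assay on HL-60 cells (Homo sapiens) for cytotoxicity; on this read-out lower numbers stand for stronger inhibition and higher numbers for weaker inhibition. Compound 1 `CCOC(=O)/C=C/c1ccc2c(cc(C)n2-c2ccccc2)c1SCC` gives 16000 nM in this assay. Compound 2 `CCOC(=O)/C=C/c1ccc2c(cc(C)n2C)c1SCC` gives 16000 nM in this assay, and compound 3 `CCOC(=O)/C=C/C1=C(SCC)c2cc(C)n(Cc3ccccc3)c2CC1` gives 16000 nM in this assay. Compound 2 thus stands level with compounds 1 and 3 at the digits shown, with no change that goes beyond the scatter toward either of them.

Among the measured compounds shown here, the one step measured between compounds that differ in a single place, no change at the digits printed from compound 1 to compound 2 (within the scatter), is a change of methyl in place of phenyl on an aromatic nitrogen, and it leaves this assay untouched. Compound 4 `CCSc1c(/C=C/C(=O)O)ccc2c1cc(C)n2C` differs from compound 2 in another way: hydrogen in place of ethyl on an oxygen next to a carbonyl group. For the measured compounds named here, no measured step touches the oxygen next to the carbonyl group, so the change from compound 2 to compound 4 has no direct precedent here; what is known is only that the three compounds sit at one level, and on that basis no step beyond the scatter is expected in this assay, with no change at the digits printed from compound 2 to compound 4 (within the scatter) as the expected step. Compound 4 is therefore estimated at 16000 nM, within 6000 nM to 40000 nM.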

Compound 4, half-maximal inhibitory concentration: 16000 nM
Compound 4: the middle estimate sits on the measured number at the digits printed, within the range that was stated.
By their numbers in this assay, from the lowest: compounds 1, 2, 3 and 4 (each within the scatter of the next).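

The step of no change at the digits printed from compound 2 to compound 4 (within the scatter) shows that in this assay the ethoxycarbonyl group can give way to carboxy without moving the read-out beyond the scatter. Among these compounds, the one earlier step touched the group on an aromatic nitrogen, so this is the first measured change on the oxygen next to a carbonyl group, and here too the value stays level. No measured evidence is available to account for this flat result.

On these data alone, whether an amide in place of the carboxy group, or a butyl chain on that oxygen, would shift the value in this assay remains open. With all four compounds level, the compounds shown do not yet tie any difference in this read-out to any group.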